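Anilinomethyl amide in the arylpiperazine melanocortin 4 series

The source may report more compounds than this note shows. Statements on the series, on what has been measured and on what is new or still open speak of the compounds shown alone.

Of the compounds shown here, three sharing one core have been measured in an assay on HEK293 cells for displacement of a labelled ligand from Melanocortin receptor 4 (Homo sapiens); on this read-out higher numbers stand for weaker inhibition and lower numbers for stronger inhibition. Compound 3 `COc1ccc(CC(C)C(=O)N2CCN(c3ccc(C(F)(F)F)cc3[C@@H](N)CC(C)C)CC2)cc1` gives 120 nM, the lowest number of the three. Compound 1 `CC(C)C[C@H](N)c1cc(C(F)(F)F)ccc1N1CCN(C(=O)COc2ccc3ccccc3c2)CC1` gives 2000 nM, and compound 2 `CC(C)C[C@H](N)c1cc(C(F)(F)F)ccc1N1CCN(C(=O)CCC2CCCCC2)CC1` gives 5700 nM. The steps are a 17-fold lower number from compound 1 to compound 3 (1.22 log units; beyond the scatter) and a 48-fold lower number from compound 2 to compound 3 (1.68 log units; beyond the scatter), both large; between the two weaker compounds the step is a 2.9-fold higher number from compound 1 to compound 2 (0.45 log units; beyond the scatter).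

Compound 4 `CC(C)C[C@H](N)c1cc(C(F)(F)F)ccc1N1CCN(C(=O)CNc2ccccc2)CC1` differs from compound 3 in one place: anilinomethyl in place of 1-(4-methoxybenzyl)ethyl on a carbonyl carbon. Going by the values given here, the steps that bear on this change are the two large ones into compound 3, which show that replacing the 1-(4-methoxybenzyl)ethyl by either a ((naphthalen-2-yl)oxy)methyl or a 2-cyclohexylethyl costs a great deal in this assay. Anilinomethyl is closer in shape to the ((naphthalen-2-yl)oxy)methyl of compound 1 than to the group it replaces, so a large step in the same direction is expected. Compound 4 is therefore estimated at 1500 nM in this assay, in the range 400 nM to 6000 nM. The step this implies, a 13-fold higher number from compound 3 to compound 4 (1.10 log units; beyond the scatter), is expected to lie well beyond the scatter.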

Compound 4, inhibition constant: 3600 nM
The estimate for compound 4 lay 2.4-fold (0.38 log units) below the measured number; the range from low to high includes it.
By their numbers in this assay, from the lowest: compound 3; then compounds 1, 4 and 2 (each within the scatter of the next, the first and the last beyond it).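

In this assay, anilinomethyl in place of 1-(4-methoxybenzyl)ethyl on the carbonyl carbon gives a 30-fold higher number from compound 3 to compound 4 (1.48 log units; beyond the scatter), so a third replacement, and the first to bring in a hydrogen-bond donor, also fails to hold the value of compound 3. On the saturated chain carbon bound to a carbonyl carbon, anilino in place of cyclohexylmethyl gives a 1.6-fold lower number from compound 2 to compound 4 (0.20 log units; within the scatter) and anilino in place of (naphthalen-2-yl)oxy gives a 1.8-fold higher number from compound 1 to compound 4 (0.26 log units; within the scatter), so compound 4 cannot be separated from either compound, although those two stand apart by a 2.9-fold higher number from compound 1 to compound 2 (0.45 log units; beyond the scatter). No measurement at hand bears on the reason for these results.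

Open, on these data alone, is whether the methoxy or the branching methyl of the 1-(4-methoxybenzyl)ethyl group carries the low number of compound 3; a plain 1-benzylethyl group and an unbranched 4-methoxyphenethyl group would separate the two. Also open, as far as these compounds go, is what the anilino hydrogen contributes, which a phenoxy or methylated anilino group on the same chain carbon would test.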